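Chloro for difluoromethoxy on a non-cytotoxic amide

The compounds below may be only part of what the source reports. "The series", "measured", "known", "first", "only" and "open" are said of these compounds alone.

Measured compounds:
compound 1, `CCCCCN1C(=O)C/C(=C\c2cccc(C(=O)Nc3ccc(C)cc3)c2)C1=O`: > 100000 nM
compound 2, `Cc1ccc(N2C(=O)C/C(=C\c3cccc(C(=O)Nc4cccc(F)c4)c3)C2=O)cc1`: > 100000 nM
compound 3, `O=C(Nc1ccc(OC(F)F)cc1)c1cccc(/C=C2\CC(=O)N(c3ccccc3)C2=O)c1`: > 100000 nM

All three were tested in an ADME assay on NCM460 cells (Homo sapiens) for cytotoxicity, read by MTT assay, with a stated time of 72 h; a higher number here means a weaker inhibitor, a lower number a stronger inhibitor. Compound 3 gives > 100000 nM, which is a limit of the assay and not a number. The same holds for every value in the set, as the limit of > 100000 nM in this assay, at which 3 of the 3 values shown sit, shows, so compound 3 stands at the limit together with compound 1 and compound 2, and nothing separates the three within this assay. Among the compounds with values here, no pair of measured compounds differs in a single place, so no measured step is available to calibrate the change that follows.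

Compound 4, `O=C(Nc1ccc(Cl)cc1)c1cccc(/C=C2\CC(=O)N(c3ccccc3)C2=O)c1`, is the untested partner of compound 3. The difference is chloro in place of difluoromethoxy on an aromatic carbon. Since every measured compound sits at the limit, there is no basis for expecting this change to move the read-out in either direction; the expectation is a step of none beyond the scatter, that is a step that the limit leaves unreadable from compound 3 to compound 4. Compound 4 is therefore expected to give about 150000 nM in this assay, with a range from 60000 nM to 400000 nM, and most likely to be reported again as a limit rather than as a number.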

Compound 4, half-maximal inhibitory concentration: > 100000 nM
Compound 4: a limit, no number; the forecaster's own chance of this, stated with the estimate: 85%; the middle value does not contradict the limit.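

In this assay compound 4 gives > 100000 nM, which is a limit of the assay and not a number. Compound 3 also stands at a limit, so no step can be read between compound 3 and compound 4, because all the values sit there: the limit of > 100000 nM in this assay, at which 4 of the 4 values shown sit. The compounds shown leave open whether any of them would give a measurable value in this assay.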